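Compound 3: chloro in place of fluoro

The source may hold more compounds than are shown below. What is called first, only, known or untested is meant among the compounds shown, and "the series" means these compounds.

In a functional assay on a cell-free system (plasma, Oryctolagus cuniculus) for inhibition, with stated times of 5 min, 1 min and 6 min (a higher number here means a weaker inhibitor, a lower number a stronger inhibitor), compound 1 (`CCOC(=O)c1c(C)nc(-c2cccc(C#N)c2)n1C`) gives 22100 nM and compound 2 (`CCOC(=O)c1c(C)nc(-c2cccc(C#N)c2)n1OCc1ccccc1F`) gives 8990 nM as the lower of the two numbers, which makes it the stronger inhibitor of the pair. Compound 3 (`CCOC(=O)c1c(C)nc(-c2cccc(C#N)c2)n1OCc1ccccc1Cl`) differs from compound 2 by chloro in place of fluoro on an aromatic carbon and carries chloro in place of fluoro on an aromatic carbon, ortho to a large group. Among the measured compounds shown here, no measured step compares fluoro with chloro, so the evidence is thin. For the measured compounds named here, the only measured step, with (2-fluorobenzyl)oxy in place of methyl on an aromatic nitrogen, is a 2.5-fold lower number from compound 1 to compound 2 (0.39 log units; beyond the scatter) and sets a modest scale for a much larger replacement. On that scale, the expected change is a 1.1-fold lower number from compound 2 to compound 3 (0.05 log units; within the scatter) and no shift beyond the scatter is expected. For compound 3 the estimated value is 8000 nM (4000 nM to 16000 nM).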

Compound 3, half-maximal inhibitory concentration: 8710 nM
The estimate for compound 3 lay 1.1-fold (0.04 log units) below the measured number; the measured number falls inside the stated range.
By their numbers in this assay, from the lowest: compounds 3 and 2 (each within the scatter of the next); then compound 1.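

In this assay, chloro in place of fluoro on this aromatic carbon, ortho to a large group, gives a 1.0-fold lower number from compound 2 to compound 3 (0.01 log units; within the scatter), so the two halogens cannot be told apart at this position. The step from the methyl compound remains with chloro as it did with fluoro: a 2.5-fold lower number from compound 1 to compound 3 (0.40 log units; beyond the scatter), alongside a 2.5-fold lower number from compound 1 to compound 2 (0.39 log units; beyond the scatter), so the modest advantage of the benzyl-type ether over methyl on the aromatic nitrogen does not depend on which of these two halogens is present. Nothing available here bears on why fluoro and chloro read alike.

From the compounds shown here alone, with only two halogens at this position, it remains open how a methoxy group or an amine would read on the same carbon. Also open, going by these compounds, is whether a longer alkyl chain on the aromatic nitrogen would match the (2-chlorobenzyl)oxy group.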